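Compound 3: trifluoromethyl in place of cyano

A few compounds are considered here, and "the series" means these few. Any claim that something is new, unique, unknown or untested is made for them only; others in the source may bear on it.

Measured so far:
compound 1 `N#Cc1ccc(-c2nc(N)c3cc(CN4CCC(F)CC4)sc3n2)cc1` — 8430 nM
compound 2 `N#Cc1ccc(-c2nc(N)c3cc(CN4CC=CC4)sc3n2)cc1` — 2350 nM

In an assay on CHO-K1 cells for antagonist activity at adenosine receptor A1 (Homo sapiens), read by a beta-galactosidase reporter, with stated times of 15 min and 6 h (a higher number here means a weaker inhibitor, a lower number a stronger inhibitor), compound 1 gives 8430 nM, the highest of the two numbers. Compound 2 gives 2350 nM, and the step of a 3.6-fold lower number from compound 1 to compound 2 (0.55 log units; beyond the scatter) concerns the group on the saturated chain carbon, not the aromatic ring. Compound 3 `Nc1nc(-c2ccc(C(F)(F)F)cc2)nc2sc(CN3CCC(F)CC3)cc12` differs from compound 1 by trifluoromethyl in place of cyano on an aromatic carbon. Going by the values given here, no measured step touches that position, so the only anchor is the number for compound 1. For compound 3 no step beyond the scatter is expected, a 1.1-fold lower number from compound 1 to compound 3 (0.02 log units; within the scatter), giving an estimate of 8000 nM with a range from 2500 nM to 25000 nM.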

Compound 3, inhibition constant: 3560 nM
Beside the measured number, compound 3's estimate is 2.2-fold (0.35 log units) above it; the measured number falls inside the stated range.
By their numbers in this assay, from the lowest: compounds 2 and 3 (each within the scatter of the next); then compound 1.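

In this assay, the position on the six-membered aromatic ring of carbon only, para to a large group, also affects the number: trifluoromethyl in place of cyano gives a 2.4-fold lower number from compound 1 to compound 3 (0.37 log units; beyond the scatter). The step is modest, and the group on the saturated chain carbon stays as in compound 1. Nothing available accounts for this step.

On these data alone, whether a methoxy group or an amine at this position would give a similar number remains open. Also open, as far as these compounds go, is whether the step holds with the five-membered ring group of compound 2 on the saturated chain carbon.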